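Thiosemicarbazone series: removing drawn double-bond geometry

A few compounds are considered here, and "the series" means these few. Any claim that something is new, unique, unknown or untested is made for them only; others in the source may bear on it.

Measured compounds:
- compound 1, `C/C(=N\NC(=S)Nc1cccc(I)c1)c1ccccn1`, 61 nM in a functional assay on T98G cells (Homo sapiens) for cytotoxicity, read by MTT assay, with a stated time of 48 h; a lower number here means a stronger inhibitor, a higher number a weaker inhibitor
- compound 2, `C/C(=N\NC(=S)Nc1ccccc1[N+](=O)[O-])c1ccccn1`, 6.61 nM in this assay
- compound 3, `C/C(=N/NC(=S)Nc1cccc([N+](=O)[O-])c1)c1ccccn1`, 140 nM in this assay

All three share the same core, a hydrazone carrying a thiourea linked to a substituted phenyl ring. Compound 2 holds the lowest number of the three in this assay and is the strongest inhibitor here: its gap to compound 1, the nearest of the others, lies beyond the scatter, and its gap to compound 3, the furthest, lies further beyond it. Compounds 1 and 3 stand well apart from compound 2 and also apart from each other.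

Compound 4, `CC(=NNC(=S)Nc1ccccc1[N+](=O)[O-])c1ccccn1`, is compound 2 drawn without geometry at the hydrazone double bond. the two compounds have the same atoms and bonds; at least one stereo element is drawn with a configuration in one of them and without one in the other: 1 of 1 stereo elements differ; a double bond is drawn E in compound 2 and without a configuration in compound 4 No atom leaves and none enters. Within the data shown here, since the two structures coincide in every atom and bond, no step in this assay beyond the scatter is expected in either direction; the estimated step is a 1.0-fold lower number from compound 2 to compound 4 (0.00 log units; within the scatter). Compound 4 is therefore expected to give about 6.6 nM, with a range of 3.3 nM to 13 nM in this assay, essentially repeating compound 2.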

Compound 4, half-maximal inhibitory concentration: 6.6 nM
Compound 4: the middle estimate sits on the measured number at the digits printed, and the stated range covers the measured number.
By their numbers in this assay, from the lowest: compounds 4 and 2 (each within the scatter of the next); then compound 1; then compound 3.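

In this assay, the pair gives a 1.0-fold lower number from compound 2 to compound 4 (0.00 log units; within the scatter), so leaving the geometry of the hydrazone double bond undrawn goes with no visible change at this position. Among these compounds, this is the first pair that differs in one place, and compounds 1, 2 and 3 offered no such direct reading among themselves. It gives no reading of how the geometry itself affects the number, because the only difference between the two entries lies in how this double bond is drawn: the fact that one of compounds 2 and 4 is drawn with a defined configuration and the other without, at the place where they differ.

Which geometry, or mixture of geometries, compound 4 holds remains open, so a true comparison of the two forms is still missing. Also open, from the compounds shown here alone, is how this assay responds when an amine or a carboxylic acid stands on the phenyl ring in place of the nitro group of compound 2.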